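Furan-2-yl in Place of Thiophen-2-yl: Expected Cytotoxicity

The source may report more compounds than this note shows. Statements on the series, on what has been measured and on what is new or still open speak of the compounds shown alone.

Compound 1, `Oc1cccc(-c2cc(-c3cccs3)nc(-c3ccccc3Cl)c2)c1`, gives 3990 nM in a functional assay on T47D cells (Homo sapiens) for cytotoxicity, read by CCK-8 assay and cell counting, with a stated time of 2 days; on this read-out higher numbers stand for weaker inhibition and lower numbers for stronger inhibition.
Compound 2, `Oc1cccc(-c2cc(-c3cccc(Cl)c3)nc(-c3cccs3)c2)c1`, gives 3410 nM in this assay.

Compound 1 carries the higher of the two numbers shown, yet only by the step of a 1.2-fold lower number from compound 1 to compound 2 (0.07 log units; within the scatter), which puts a 3-chlorophenyl in place of a 2-chlorophenyl group on an aromatic carbon and stays within the scatter, so the two compounds cannot be told apart on this read-out. Compound 3, `Oc1cccc(-c2cc(-c3ccco3)nc(-c3ccccc3Cl)c2)c1`, has not been measured. It differs from compound 1 in one place: furan-2-yl in place of thiophen-2-yl on an aromatic carbon. Going by the values given here, no measured step touches this exchange of one five-membered aromatic ring for another; the single step available concerns the chlorophenyl group and was itself within the scatter, so it offers no direction. On the numbers shown there is no ground to expect a step beyond the scatter in this assay in either direction. Compound 3 is therefore expected to sit close to compound 1. The step expected for compound 3 is a 1.0-fold higher number from compound 1 to compound 3 (0.00 log units; within the scatter). The value estimated for compound 3 is 4000 nM, between 1500 nM and 11000 nM.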

Compound 3, half-maximal inhibitory concentration: 2010 nM
Estimate against measurement, compound 3: 2.0-fold (0.30 log units) above, and the stated range covers the measured number.
By their numbers in this assay, from the lowest: compounds 3, 2 and 1 (each within the scatter of the next).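

Furan-2-yl in place of thiophen-2-yl, on the aromatic carbon next to the ring nitrogen, gives a 2.0-fold lower number from compound 1 to compound 3 (0.30 log units; within the scatter) in this assay. This is the first step shown at this position, and it swaps the sulfur of one five-membered aromatic ring for the oxygen of another while the counts of heavy atoms, donors and acceptors stay the same; with the 2-chlorophenyl group in place, the read-out does not separate the two rings. Nothing shown accounts for the size of this step, and no measurement bearing on it accompanies these numbers.

The two rings are close relatives, so the compounds shown leave open whether a clearly different group at this position, such as an open-chain amine, a carboxylic acid or a longer alkyl chain, would give a step beyond the scatter. They also leave open whether the same exchange of thiophen-2-yl for furan-2-yl would read alike alongside the 3-chlorophenyl group of compound 2, and whether a methoxy group in place of the hydroxyl of the 3-hydroxyphenyl group would move the number at all.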